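A few compounds are considered here, and "the series" means these few. Any claim that something is new, unique, unknown or untested is made for them only; others in the source may bear on it.

Measured so far in a functional assay on MDA-MB-231 cells (Homo sapiens) for inhibition, read by MTT assay, with a stated time of 48 h; on this read-out higher numbers stand for weaker inhibition and lower numbers for stronger inhibition: compound 1 `COc1cc(/C=C/c2ccc(NC(=O)/C=C/c3cc(OC)c(O)c(OC)c3)cc2)cc(OC)c1` gives 7130 nM; compound 2 `COc1cc(/C=C/c2ccc(NC(=O)/C=C/c3ccc(F)cc3)cc2)cc(OC)c1` gives 9390 nM; compound 3 `COc1cc(/C=C/c2ccc(NC(=O)/C=C/c3cccc(F)c3)cc2)cc(OC)c1` gives 17300 nM.

Compound 3 sits at the weak end of this small set: a 2.4-fold higher number from compound 1 to compound 3 (0.38 log units; beyond the scatter) lies beyond the scatter, while a 1.8-fold higher number from compound 2 to compound 3 (0.27 log units; within the scatter) does not separate compound 3 from compound 2. Compound 4 `COc1cc(/C=C/c2ccc(NC(=O)/C=C/c3ccccn3)cc2)cc(OC)c1` differs from compound 3 by pyridin-2-yl in place of 3-fluorophenyl on a double-bonded chain carbon bound to a double-bonded chain carbon. Among the compounds with values here, no measured step replaces the aryl with a heteroaryl, so the bearing is indirect; the aryl exchanges seen so far, a 1.3-fold higher number from compound 1 to compound 2 (0.12 log units; within the scatter), a 2.4-fold higher number from compound 1 to compound 3 (0.38 log units; beyond the scatter) and a 1.8-fold higher number from compound 2 to compound 3 (0.27 log units; within the scatter), were all modest. In this assay a step of similar, modest size is therefore expected, more likely toward a lower number than a higher one. Compound 4 is estimated at 12000 nM, within 5000 nM to 35000 nM, which corresponds to an expected 1.4-fold lower number from compound 3 to compound 4 (0.16 log units; within the scatter).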

Compound 4, half-maximal inhibitory concentration: 3400 nM
Estimate against measurement, compound 4: 3.5-fold (0.55 log units) above, and the stated range ends above it.
By their numbers in this assay, from the lowest: compound 4; then compounds 1, 2 and 3 (each within the scatter of the next, the first and the last beyond it).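

In this assay, pyridin-2-yl on a double-bonded chain carbon bound to a double-bonded chain carbon separates compound 4 from all three phenyl-bearing compounds (a 5.1-fold lower number from compound 3 to compound 4 (0.71 log units; beyond the scatter); a 2.8-fold lower number from compound 2 to compound 4 (0.44 log units; beyond the scatter); a 2.1-fold lower number from compound 1 to compound 4 (0.32 log units; beyond the scatter)). Compound 4 therefore has the lowest number of the four, and its ring is the only one shown with a hetero atom. Nothing available gives a reason for these steps.

Going by these compounds, whether pyridin-3-yl or pyridin-4-yl would match pyridin-2-yl here remains open. So does the outcome with a second ring nitrogen, as in pyrimidin-2-yl.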